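The source may hold more compounds than are shown below. What is called first, only, known or untested is meant among the compounds shown, and "the series" means these compounds.

In an assay for binding affinity to Alpha-1B adrenergic receptor (Homo sapiens) (a higher number here means a weaker inhibitor, a lower number a stronger inhibitor), compound 3 `CN1CCCCC(n2nc(Cc3ccc(Cl)cc3)c3ccccc3c2=O)C1` gives 158 nM, the lower of the two numbers in hand. Compound 2 `CN(C)CCn1nc(Cc2ccc(Cl)cc2)c2ccccc2c1=O` gives 200 nM in this assay. Compound 1 `CN1CCC[C@@H]1Cn1nc(CC2CCCCC2)c2ccccc2c1=O` reaches only a limit in this assay, > 1990 nM, the one limit among the three values (the limit of > 1990 nM in this assay, at which 1 of the 3 values shown sits).

Among the measured compounds shown here, the single measured step that touches the side chain on the aromatic nitrogen, a 1.3-fold lower number from compound 2 to compound 3 (0.10 log units; within the scatter), changed an open-chain amine for a ring-bound one without moving the number beyond the scatter. Compound 4 `CN1CCCC1CCn1nc(Cc2ccc(Cl)cc2)c2ccccc2c1=O` reshapes that same side chain again: 2-(1-methylpyrrolidin-2-yl)ethyl in place of 1-methylazepan-3-yl on an aromatic nitrogen. The amine stays, the atom count stays, and the 4-chlorobenzyl group and the shared core are untouched, so nothing in the measured steps points to a change in this assay beyond the scatter.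

Compound 4 is therefore expected to give about 180 nM in this assay, within 70 nM to 500 nM. The corresponding step is estimated as a 1.1-fold higher number from compound 3 to compound 4 (0.06 log units; within the scatter).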

Compound 4, inhibition constant: 316 nM
The estimate for compound 4 lay 1.8-fold (0.24 log units) below the measured number, and the stated range covers the measured number.
By their numbers in this assay, from the lowest: compounds 3, 2 and 4 (each within the scatter of the next). At a limit, above all of these: compound 1.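

The exchange of 1-methylazepan-3-yl for 2-(1-methylpyrrolidin-2-yl)ethyl on the aromatic nitrogen gives a 2.0-fold higher number from compound 3 to compound 4 (0.30 log units; within the scatter) in this assay, and 1-methylpyrrolidin-2-yl in place of dimethylamino on the chain gives a 1.6-fold higher number from compound 2 to compound 4 (0.20 log units; within the scatter) on the same shared core. With the 4-chlorobenzyl group held constant, an open-chain amine, a seven-membered ring and a five-membered ring carried on a chain therefore cannot be told apart at this position in this assay. Nothing in the data shown accounts for any property behind these steps.

Compound 1 gives only a limit, > 1990 nM, and differs from the others in more than one place, so it cannot be read for the side chain alone. From the compounds shown here alone, whether a longer chain to the dimethylamino group, a 1-methylpiperidin-4-yl group or a carboxylic acid in place of the amine would hold this level remains open.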